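The source may hold more compounds than are shown below. What is called first, only, known or untested is meant among the compounds shown, and "the series" means these compounds.

Compound 1, `Cn1ccc2cc(-c3cnccc3/C=C/C(=O)O)ccc21`: 7260 nM
Compound 2, `O=C(/C=C/c1ccncc1-c1ccc2ccccc2c1)NC1CC1`: 6180 nM
Compound 3, `O=C(/C=C/c1ccncc1-c1ccc2cc[nH]c2c1)N1CCOCC1`: > 30000 nM

All three were tested in a functional assay on HCT-116 cells (Homo sapiens) for inhibition, read by MTT assay, with a stated time of 72 h; on this read-out higher numbers stand for weaker inhibition of growth and lower numbers for stronger inhibition of growth. Compound 1 gives 7260 nM and compound 2 gives 6180 nM, two values that lie within the usual scatter of each other. For compound 3 the read-out is not a number but a limit of the assay, > 30000 nM. Compound 3 therefore stands at the limit of > 30000 nM in this assay, at which 1 of the 3 values shown sits, the weakest end of what the assay reports, with no figure attached to it.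

The next compound is compound 4, `CNC(=O)/C=C/c1ccncc1-c1ccc2cc[nH]c2c1`. It differs from compound 3 in one place: methylamino in place of morpholin-4-yl on a carbonyl carbon. Among the measured compounds shown here, no pair of measured compounds differs in only one place, so the data give no measured step from which the size of this change can be read. Compound 3 being a limit, any expected step from it can only be stated relative to that limit. Compound 4 is expected to inhibit growth somewhat more strongly than the limit of compound 3, an expected step of an at least 2.0-fold lower number from compound 3 to compound 4 (0.30 log units; that floor lies within the scatter), with a fair chance that the assay again returns only a limit. The estimate for compound 4 in this assay is 15000 nM, expected to lie between 4000 nM and 40000 nM.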

Compound 4, concentration for 50% growth inhibition: 10400 nM
Estimate against measurement, compound 4: 1.4-fold (0.16 log units) above; the measured number falls inside the stated range.
By their numbers in this assay, from the lowest: compounds 2, 1 and 4 (each within the scatter of the next). At a limit, above all of these: compound 3.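

In this assay, the exchange of morpholin-4-yl for methylamino on a carbonyl carbon gives an at least 2.8-fold lower number from compound 3 to compound 4 (0.46 log units; beyond the scatter), the first step that can be read for any pair among these compounds. Compound 3 stays a limit of the assay: the limit of > 30000 nM in this assay, at which 1 of the 4 values shown sits. The step shows that this position responds to the change, and that the ring of morpholin-4-yl can be given up while a measurable inhibition of growth is kept; the change also swaps 6 heavy atoms for 2 and brings in a hydrogen-bond donor, and one step cannot tell which of these differences counts.

As far as these compounds go, it remains open whether the gain goes with the loss of the ring or with the amide hydrogen, and a dimethylamino group or a piperidin-1-yl ring on the same carbonyl carbon would separate the two. Compound 1 and compound 2 each differ from compound 4 in more than one place, so how a cyclopropylamino group or a free carboxylic acid compares with methylamino on the core of compound 4 also stays unanswered.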